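Adding a Second Chloro Group to Compound 3

The source may hold more compounds than are shown below. What is called first, only, known or untested is meant among the compounds shown, and "the series" means these compounds.

Compound 3 `O=CN1CCN(c2ccc(Cl)cc2)C1=S` gives 15400 nM in a functional assay on OVCAR-3 cells (Homo sapiens) for inhibition, read by sulforhodamine B assay, with a stated time of 48 h (a higher number here means a weaker inhibitor of growth, a lower number a stronger inhibitor of growth), the lowest of the three numbers measured, though all three lie within the scatter of one another: compound 1 `N#C/C(=C\N1CCN(C(=O)c2ccco2)C1=S)C(=O)Nc1ccc(Cl)cc1` gives 15500 nM, and compound 2 `N#C/C(=C\N1CCN(C(=O)c2ccco2)C1=S)C(=O)c1ccccc1` gives 18200 nM. Among the measured compounds shown here, the only measured step, a 1.2-fold higher number from compound 1 to compound 2 (0.07 log units; within the scatter), concerns another change on a different core and so gives no direct guide. Compound 4 `O=CN1CCN(c2ccc(Cl)c(Cl)c2)C1=S` differs from compound 3 by chloro in place of hydrogen on an aromatic carbon. For the measured compounds named here, no measured pair shows the effect of such an added chloro group, and the single measured step stayed within the scatter, so no step beyond the scatter is expected in this assay. Compound 4 is therefore estimated at 14000 nM, with a range from 6000 nM to 32000 nM. This estimate is expected to mean a 1.1-fold lower number from compound 3 to compound 4 (0.04 log units; within the scatter).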

Compound 4, concentration for 50% growth inhibition: 15000 nM
For compound 4 the middle estimate is 1.1-fold (0.03 log units) below the measured one, and the stated range covers the measured number.
By their numbers in this assay, from the lowest: compounds 4, 3, 1 and 2 (each within the scatter of the next).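

At this place, on an aromatic carbon ortho to a chloro group and meta to a group of 8 heavy atoms, the added chloro group leaves the number in this assay within the scatter, a 1.0-fold lower number from compound 3 to compound 4 (0.01 log units; within the scatter). Among the compounds shown here, this is the first pair to isolate the change on this aromatic ring, and it shows that a second chlorine there costs no measurable growth inhibition. No measured evidence bears on this outcome. From the compounds shown here alone, whether a group such as methoxy or an amine at this place would move the number beyond the scatter remains open. Also open, going by these compounds, is whether the same chloro change would behave alike on the core of compound 1.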